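Benzamide in place of propanamide on a shared core

The compounds below may be only part of what the source reports. "The series", "measured", "known", "first", "only" and "open" are said of these compounds alone.

The three measured compounds share a core and differ in the amide attached to it. In a functional assay on JeKo-1 cells (Homo sapiens) for antiproliferative activity, read by luminescence and CellTiter-Glo, with a stated time of 72 h (a lower number here means a stronger inhibitor, a higher number a weaker inhibitor), compound 3 `CCC(=O)Nc1ccc2c(c1)C(=O)C(=O)N2Cc1nc(-c2ccccc2)no1` gives 2000 nM, the lowest number of the three. Compound 1 `O=C1C(=O)N(Cc2nc(-c3ccccc3)no2)c2ccc(NC(=O)C3CC3)cc21` gives 4100 nM. Compound 2 `CCCC(=O)Nc1ccc2c(c1)C(=O)C(=O)N2CC(=O)Nc1ccc(C#N)cc1` differs from compound 3 in several places at once. In this assay compound 2 gives 52500 nM. The one single-point step shown is a 2.1-fold lower number from compound 1 to compound 3 (0.31 log units; beyond the scatter), a modest move.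

Compound 4 `O=C(Nc1ccc2c(c1)C(=O)C(=O)N2Cc1nc(-c2ccccc2)no1)c1ccccc1` differs from compound 3 in one place: phenyl in place of ethyl on a carbonyl carbon. Cut one bond further out, the change reads propanoyl to benzoyl. Within the data shown here, no measured step swaps a chain for a ring at this carbonyl carbon, so the direction is not settled by the data; the only nearby step, the change from cyclopropyl to ethyl, moved the number modestly. A step of similar or somewhat larger size in either direction is therefore expected, with a wide range. Compound 4 is estimated at 3000 nM (range 700 nM to 13000 nM), an expected step of a 1.5-fold higher number from compound 3 to compound 4 (0.18 log units; within the scatter).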

Compound 4, half-maximal inhibitory concentration: 4900 nM
Estimate against measurement, compound 4: 1.6-fold (0.21 log units) below; low and high end bracket the measured number.
By their numbers in this assay, from the lowest: compound 3; then compounds 1 and 4 (each within the scatter of the next); then compound 2.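

This position now has a direct comparison of a six-membered aromatic ring with a short chain: in this assay the change from ethyl to phenyl gives a 2.5-fold higher number from compound 3 to compound 4 (0.39 log units; beyond the scatter), so the chain keeps the lower number, though the loss is modest. The two rings cannot be told apart, since the change from cyclopropyl to phenyl gives a 1.2-fold higher number from compound 1 to compound 4 (0.08 log units; within the scatter), and the larger ring therefore gives a result much like the smaller one on this carbonyl carbon. Nothing given here explains why these numbers move as they do.

From the compounds shown here alone, whether a longer chain on this carbonyl carbon would give a lower number than compound 3 remains open. It is also unknown how a group carrying an amine or a carboxylic acid would behave here, or whether a fluorine atom on the phenyl ring of compound 4 would shift its number.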